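Dropping the hydroxy group: no movement expected at the limit

A few compounds are considered here, and "the series" means these few. Any claim that something is new, unique, unknown or untested is made for them only; others in the source may bear on it.

Compound 3 `COc1ccc2[nH]c(-c3cc[se]c3)cc(=O)c2c1O` has been tested in an ADME assay on Detroit 551 cells (Homo sapiens) for cytotoxicity, read by MTT assay, with a stated time of 48 h; a higher number here means a weaker inhibitor, a lower number a stronger inhibitor. In this assay compound 3 gives > 100000 nM, which is a limit of the assay and not a number. Compound 2 `COc1ccc2[nH]c(-c3cc[se]c3)cc(=O)c2c1OC` stands at the same place: in this assay compound 2 gives > 100000 nM, again a limit. Compound 1 `COc1ccc2[nH]c(-c3ccc(C)[se]3)cc(=O)c2c1` differs at more than one place, and in this assay compound 1 gives > 10000 nM, also a limit. Among the three values shown, compound 3 therefore sits with compound 2 at the limit of > 100000 nM in this assay, at which 2 of the 3 values shown sit, while compound 1 rests at the limit of > 10000 nM in this assay, at which 1 of the 3 values shown sits. Among the measured compounds shown here, the only step between measured compounds that changes a single place is a step that the two limits leave unreadable from compound 2 to compound 3, and with both ends resting on the same limit its size cannot be read.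

Compound 4 `COc1ccc2[nH]c(-c3cc[se]c3)cc(=O)c2c1` is the next compound to be measured. It differs from compound 3 by hydrogen in place of hydroxy on an aromatic carbon. For the measured compounds named here, the one measured step bears on it only loosely: it also alters an oxygen substituent on the shared core, but it gives no readable size, so no direction can be taken from it. With both neighbours of this kind sitting at the limit, the reasonable expectation is a step of a number no higher from compound 3 to compound 4 (the limit leaves the size open) for compound 4, that is, nothing beyond the scatter. Compound 4 is accordingly expected in this assay to come out near 100000 nM, estimated to lie between 30000 nM and 300000 nM, most likely reported again as a limit.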

Compound 4, half-maximal inhibitory concentration: > 10000 nM
Compound 4: no number, only a limit (the forecaster's own chance of this, stated with the estimate: 85%); the middle value lies beyond the limit too.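

In this assay compound 4 gives > 10000 nM, which is a limit of the assay and not a number. Among the compounds shown here, no step from compound 1, compound 2 or compound 3 to compound 4 can be read, as all four values are limits. The compounds shown leave open what number any of them would reach in this assay, and whether losing the hydroxy or methoxy group changes it at all.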